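From pyridin-2-yl to isopropyl in compound 4

This account rests on a few compounds, and the source may have more. Where it says the series, first, only, none or still open, it means among the compounds named here.

In a physicochemical assay for lipophilicity, at pH 7.4 (on this read-out higher numbers stand for higher lipophilicity and lower numbers for lower lipophilicity), compound 3 `Cc1cc(NC(=O)OCc2ccccn2)nn1Cc1cc(Cl)ccc1OCc1ccccc1` gives 3.1 and compound 1 `Cc1cc(C(=O)Nc2ccc(F)cc2)nn1Cc1cc(Cl)ccc1OCc1ccccc1` gives 3, two values within the scatter of each other. Compound 2 `CC(=O)Nc1cc(C)n(Cc2cc(Cl)ccc2OCc2ccccc2)n1` reports only a limit, > 3.7. Compound 4 `Cc1cc(NC(=O)OCC(C)C)nn1Cc1cc(Cl)ccc1OCc1ccccc1` differs from compound 3 by isopropyl in place of pyridin-2-yl on a saturated chain carbon bound to an oxygen next to a carbonyl group, which also reads as (pyridin-2-yl)methoxy to isobutoxy. The measured step that bears on this is a number at least 0.60 log units lower from compound 2 to compound 3 (beyond the scatter), where (pyridin-2-yl)methoxy took the place of methyl on a carbonyl carbon, and that step rests on a limit. Going by a number at least 0.60 log units lower from compound 2 to compound 3 (beyond the scatter), compound 4, which carries no pyridin-2-yl, is expected to move the opposite way in this assay by a modest step. The expected step is a number 0.80 log units higher from compound 3 to compound 4 (beyond the scatter). For compound 4 the estimated value is 3.9, within a range of 3.4 to 4.4.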

Compound 4, distribution coefficient: 3.3
The estimate for compound 4 lay 0.60 log units above the measured number; measured number outside the range, below it.
By their numbers in this assay, from the lowest: compounds 1, 3 and 4 (each within the scatter of the next). At a limit, above all of these: compound 2.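

In this assay, replacing pyridin-2-yl with isopropyl on this saturated chain carbon gave a number 0.20 log units higher from compound 3 to compound 4 (within the scatter), so this change did not separate the two compounds, and the isobutoxycarbonylamino group likewise gave a number 0.30 log units higher from compound 1 to compound 4 (within the scatter). Isobutoxy in place of methyl on a carbonyl carbon gave a number at least 0.40 log units lower from compound 2 to compound 4 (beyond the scatter), showing that a step of this kind beyond the scatter did not depend on pyridin-2-yl. Compound 2 reports only a limit, so this step has no exact size: the limit of > 3.7 in this assay, at which 1 of the 4 values shown sits.

The compounds shown leave open whether an amine, a carboxylic acid or a longer chain in place of isopropyl would give a step beyond the scatter from compound 3.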